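A Second Chloro on the Aryl Ring

The compounds below may be only part of what the source reports. "The series", "measured", "known", "first", "only" and "open" are said of these compounds alone.

Measured so far in a functional assay on the whole organism (Pleural cavity) for inhibition, with Rattus norvegicus as the target, at a dose of 25 mg/kg; on this read-out higher numbers stand for more inhibition at the one dose given (going by the name of the read-out) and lower numbers for less inhibition:
compound 1, `CC1(C)C(=O)N(Cc2ccccc2)c2ncccc21`, gives 12%
compound 2, `CC1(C)C(=O)N(Cc2ccc(Cl)cc2)c2ncccc21`, gives 6%
compound 3, `CC1(C)C(=O)N(c2cccc(Cl)c2)c2ncccc21`, gives 51%

The three compounds share a core and differ in the group on the amide nitrogen. Compound 3 stands highest, and its gap to compound 1 and to compound 2 is beyond the usual scatter. How the core of compound 3 differs from that of compound 1 is not broken down here.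

One change is seen twice. From compound 1 to compound 2 the change is chloro in place of hydrogen on an aromatic carbon, and the step in this assay is a number 6 percentage points lower from compound 1 to compound 2 (within the scatter). Compound 4, `CC1(C)C(=O)N(c2cc(Cl)cc(Cl)c2)c2ncccc21`, is made from compound 3 by chloro in place of hydrogen on an aromatic carbon. This is the same kind of change, though the surroundings differ: in compound 2 the chloro sits "para to a large group", in compound 4 "meta to a chloro group; meta to a large group".

Because a number 6 percentage points lower from compound 1 to compound 2 (within the scatter) stayed within the scatter, the expected step for compound 4 is a number 4 percentage points lower from compound 3 to compound 4 (within the scatter). Compound 4 is therefore estimated at 47%, between 25% and 68%.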

Compound 4, a percentage reported as inhibition, in the whole organism at one dose (the size of the read-out at that dose, not a potency): 49%
Beside the measured number, compound 4's estimate is 2 percentage points below it; measured number inside the range.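

In this assay, putting chloro in place of hydrogen on an aromatic carbon gives a number 2 percentage points lower from compound 3 to compound 4 (within the scatter). Set beside the earlier case, the change looks the same on both cores, as far as these measurements can tell: the same change on two cores in this assay, a number 6 percentage points lower (within the scatter) from compound 1 to compound 2 and a number 2 percentage points lower (within the scatter) from compound 3 to compound 4, 4 percentage points apart, within the scatter of two such steps. For the compounds shown here, this rests on only two pairs, each measured at a single dose and with the chloro in different surroundings, so it does not show that the change would leave the number just as unmoved on another core or at another place on the ring.

The compounds shown carry only hydrogen or chloro on the aromatic ring, which leaves open what a methoxy group, a trifluoromethyl group, an amine or a carboxylic acid would do there. Also open, going by these compounds, is whether a longer chain on the amide nitrogen, carrying the same chloro-substituted ring, would give a number nearer that of compound 3 or that of compound 2.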